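Cytotoxicity notes on the series: compound 3 to compound 4

The source may hold more compounds than are shown below. What is called first, only, known or untested is meant among the compounds shown, and "the series" means these compounds.

In an ADME assay on RD cells (Homo sapiens) for cytotoxicity; on this read-out higher numbers stand for lower toxicity in this test and lower numbers for higher toxicity in this test:
compound 1 `O=C1Nc2ccc(OC(F)(F)F)cc2/C1=N/NC(=S)Nc1ccccc1` gives > 25000 nM, a limit of the assay.
compound 2 `O=C1Nc2ccccc2/C1=N/NC(=S)Nc1ccc(-n2cccn2)cc1` gives > 25000 nM, a limit of the assay.
compound 3 `O=C1Nc2ccccc2/C1=N/NC(=S)Nc1ccc(Cl)cc1` gives > 25000 nM, a limit of the assay.

No value in this set is a number; all three sit at the same limit, (the limit of > 25000 nM in this assay, at which 3 of the 3 values shown sit). Among the compounds with values here, the single comparison between compounds that differ in one place, a step that the two limits leave unreadable from compound 2 to compound 3, is a step whose size the two limits leave unreadable; it was chloro in place of 1H-pyrazol-1-yl on an aromatic carbon. Compound 3 therefore stands at the limit of this assay together with the other two values, and nothing ranks it against them.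

Within the data shown here, compound 4 `O=C1Nc2ccccc2/C1=N/NC(=S)Nc1ccc(F)cc1` is not yet measured. fluoro in place of chloro on an aromatic carbon No measured step covers this change, and the only measured step is itself unreadable, so no size or direction can be drawn from the steps. Among the measured compounds shown here, because every value so far sits at the limit (the limit of > 25000 nM in this assay, at which 3 of the 3 values shown sit), the expectation is that compound 4 will also show no toxicity that the assay can number.

For compound 4 the estimated value in this assay is 30000 nM, with a range of 15000 nM to 80000 nM. The step this estimate means, a step that the limit leaves unreadable from compound 3 to compound 4, is expected to be none beyond the scatter.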

Compound 4, half-maximal cytotoxic concentration: > 25000 nM
Compound 4: only a limit was reported; the forecaster's own chance of this, stated with the estimate: 85%; the middle value does not contradict the limit.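

No step can be read from compound 3 to compound 4 or from compound 2 to compound 4, because each pair compares two limits: the limit of > 25000 nM in this assay, at which 4 of the 4 values shown sit.

The compounds shown leave open any numbered cytotoxicity in this assay, and with it any ranking among compound 1, compound 2, compound 3 and compound 4.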